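The source may report more compounds than this note shows. Statements on the series, on what has been measured and on what is new or still open speak of the compounds shown alone.

For the measured compounds named here, in a functional assay on A549 cells (Homo sapiens) for inhibition, read by MTT assay, with a stated time of 24 h (on this read-out higher numbers stand for weaker inhibition and lower numbers for stronger inhibition), compound 2 `CC1(C)[C@H]2CC[C@]1(C)N(Cc1cn(-c3ccccc3)nn1)C(=O)C2` gives 70 nM, the lower of the two numbers so far, while compound 1 `CC1(C)[C@H]2CC[C@]1(C)N(Cc1cn(-c3cccc(F)c3)nn1)C(=O)C2`, which carries a fluoro group on its aromatic ring, gives 180 nM. Compound 3 `CC1(C)[C@H]2CC[C@]1(C)N(Cc1cn(-c3ccc(Br)cc3)nn1)C(=O)C2` has not yet been measured. It keeps the shared core of compound 2 and differs in one place, phenyl to 4-bromophenyl, with bromo in place of hydrogen on an aromatic carbon, para to a large group (bromo in place of hydrogen on an aromatic carbon).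

Going by the values given here, only one measured step bears on this change, and it does so loosely: a 2.6-fold lower number from compound 1 to compound 2 (0.41 log units; beyond the scatter), a modest step beyond the scatter, in which hydrogen replaces fluoro on an aromatic carbon. Among the compounds with values here, that step concerns fluoro rather than bromo, and no measured compound carries bromo, so it serves only as a rough guide to size and direction. A modest move toward weaker inhibition is therefore expected in this assay. The expected change is a 2.1-fold higher number from compound 2 to compound 3 (0.33 log units; beyond the scatter). For compound 3 the estimated value is 150 nM, with an expected range of 50 nM to 450 nM.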

Compound 3, half-maximal inhibitory concentration: 80 nM
Beside the measured number, compound 3's estimate is 1.9-fold (0.27 log units) above it; the measured number falls inside the stated range.
By their numbers in this assay, from the lowest: compounds 2 and 3 (each within the scatter of the next); then compound 1.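

In this assay, the step of a 1.1-fold higher number from compound 2 to compound 3 (0.06 log units; within the scatter) shows that bromo, a single heavy atom on an aromatic carbon para to a large group, leaves the read-out within the scatter of the unsubstituted phenyl compound. Compounds 1 and 2 alone might have suggested that any halogen on this ring goes with a higher number, but compound 3 goes against that reading: the change to 4-bromophenyl from 3-fluorophenyl on an aromatic nitrogen is a 2.3-fold lower number from compound 1 to compound 3 (0.35 log units; beyond the scatter), a modest step beyond the scatter. No measurement shown here gives any reason for the difference between these two halogen-bearing compounds.

That step changes both the halogen and where it stands on the ring, so the compounds shown cannot separate the contribution of the halogen from that of its place. Also open, going by these compounds, is how the read-out would respond to a group other than a halogen at the place now held by bromo, such as a methoxy group, an amine or a carboxylic acid.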